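The source may hold more compounds than are shown below. What is called first, only, known or untested is meant among the compounds shown, and "the series" means these compounds.

Of the compounds shown here, three built on one shared core have been tested in a functional assay on CHO cells for antagonist activity at adenosine receptor A2b (Homo sapiens); a lower number here means a stronger inhibitor, a higher number a weaker inhibitor. Compound 1 `O=C(Nc1ncc(C(=O)O)c2nc(-c3ccco3)nn12)NC1CCCCC1` returns only a limit of the assay, > 30000 nM. Compound 2 `CCOC(=O)c1cnc(NC2CCCCC2)n2nc(-c3ccco3)nc12` likewise returns only a limit, > 10000 nM. Compound 3 `CCNc1ncc(C(=O)O)c2nc(-c3ccco3)nn12` also stops at a limit, > 10000 nM. Among the measured compounds shown here, the single measured step that the two limits leave unreadable from compound 1 to compound 3 is thus unreadable, because both ends sit at limits the limit of > 10000 nM in this assay, at which 2 of the 3 values shown sit, and (the limit of > 30000 nM in this assay, at which 1 of the 3 values shown sits), so no direction or size can be taken from it. Compound 4 `Cc1ccc(CNc2ncc(C(=O)O)c3nc(-c4ccco4)nn23)cc1` differs from compound 3 by 4-methylphenyl in place of methyl on a saturated chain carbon bound to a nitrogen on an aromatic ring. For the measured compounds named here, no measured step bears on that change. Compound 4 is therefore expected, with wide uncertainty, around 8000 nM, from 800 nM to 50000 nM. The expected step of an at least 1.2-fold lower number from compound 3 to compound 4 (0.09 log units; that floor lies within the scatter) is a guess rather than a reading.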

Compound 4, inhibition constant: > 10000 nM
Compound 4 gave a limit, no number (the forecaster's own chance of this, stated with the estimate: 55%); middle value at least 1.2-fold (0.09 log units) away from the limit.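

Compound 4 also stops at a limit, so its steps from compound 3 and from compound 1 cannot be read: the limit of > 10000 nM in this assay, at which 3 of the 4 values shown sit.

The compounds shown leave open how the groups on the shared core compare in this assay, since none of the four yet has a actual number.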